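The compounds below may be only part of what the source reports. "The series", "measured", "known", "first", "only" and "open" are said of these compounds alone.

Measured compounds:
- compound 1 `COc1ccc(-c2cn(Cc3ccccc3)nn2)cc1`: 83800 nM
- compound 2 `C1=C(c2cn(Cc3ccccc3)nn2)CCCC1`: 49600 nM

Of the compounds shown here, two sharing the same core have been tested in a functional assay on P388 cells (Mus musculus) for antiproliferative activity, read by MTT assay, with a stated time of 72 h; on this read-out lower numbers stand for stronger inhibition and higher numbers for weaker inhibition. Compound 1 `COc1ccc(-c2cn(Cc3ccccc3)nn2)cc1` gives 83800 nM in this assay, and compound 2 `C1=C(c2cn(Cc3ccccc3)nn2)CCCC1` gives 49600 nM. Compound 2 carries the lower of the two numbers, but the gap to compound 1 falls within the scatter of repeated measurements, so the two cannot be ranked against each other; both sit at weak inhibition.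

Compound 3 `CCCCc1cn(Cc2ccccc2)nn1` has not yet been measured in this assay. It differs from compound 2 in one place: butyl in place of cyclohex-1-en-1-yl on an aromatic carbon. Among the measured compounds shown here, no step between measured compounds involves a change of this kind, so there is nothing that shows how exchanging a ring for a chain at that position moves the read-out. For the measured compounds named here, the only guide is that the two measured compounds, with two different groups at the same position, land close together.

On that basis compound 3 is expected to stay near compound 2, with an estimated step of a 1.4-fold higher number from compound 2 to compound 3 (0.15 log units; within the scatter) that does not go beyond the scatter. The estimate for compound 3 in this assay is 70000 nM, with a range from 25000 nM to 200000 nM.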

Compound 3, half-maximal inhibitory concentration: 217000 nM
Beside the measured number, compound 3's estimate is 3.1-fold (0.49 log units) below it, outside the stated range (above it).
By their numbers in this assay, from the lowest: compounds 2 and 1 (each within the scatter of the next); then compound 3.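

In this assay, the group on this aromatic carbon does move the read-out: butyl in place of cyclohex-1-en-1-yl gives a 4.4-fold higher number from compound 2 to compound 3 (0.64 log units; beyond the scatter), a modest step but the first in the series to lie beyond the scatter. Compound 3 is also the only compound shown with no ring in its group at this position, and it carries the highest number of the three, though a single step cannot separate the loss of the ring from the change in carbon count or the loss of the double bond. No supporting measurement bears on why the chain differs from the ring in this way.

The compounds shown leave open whether a hexyl chain, with as many carbons as cyclohex-1-en-1-yl, would stay near compound 3 or return towards compound 2, and whether a saturated cyclohexyl ring would match compound 2. They also leave open how an amine or a carboxylic acid at this position would read out, and whether any group there could move the series away from weak inhibition.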